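Working notes on the step from compound 2 to compound 3

The source may report more compounds than this note shows. Statements on the series, on what has been measured and on what is new or still open speak of the compounds shown alone.

Two compounds of the shared core carry a measurement in an assay on isolated protein for inhibition of DNA topoisomerase 1 (Homo sapiens), with a stated time of 30 min, tested at 20 uM; on this read-out lower numbers stand for a weaker effect and higher numbers for a stronger effect at the one concentration tested. Compound 1 `Cc1cccc(-c2nc3cc(C)ccc3c(=O)[nH]2)c1` gives 56.3% there, while compound 2 `Cc1ccc2c(=O)[nH]c(-c3cccc(OC(F)(F)F)c3)nc2c1` gives 0%. Compound 2 therefore stands at the bottom of the two numbers shown, and the single step linking the pair, a number 56.3 percentage points lower from compound 1 to compound 2 (beyond the scatter), is the only measured change in the series so far.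

Compound 3 `Cc1ccc2c(=O)[nH]c(-c3cccc(C(F)(F)F)c3)nc2c1` is not yet measured. It differs from compound 2 by trifluoromethyl in place of trifluoromethoxy on an aromatic carbon. Within the data shown here, no measured step covers trifluoromethyl, so the expectation rests on the one step available: trifluoromethoxy in place of methyl on an aromatic carbon removed the whole effect seen in compound 1, as a number 56.3 percentage points lower from compound 1 to compound 2 (beyond the scatter) shows, and the change to compound 3 keeps the three fluorine atoms of that group while the one oxygen leaves. The outcome is therefore uncertain; a modest recovery is taken as the central case, though a result within the scatter of compound 2 is equally plausible. Compound 3 is expected to give about 15% in this assay, within 0% to 45%, which means an expected step of a number 15 percentage points higher from compound 2 to compound 3 (beyond the scatter).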

Compound 3, a percentage reported as inhibition, at one concentration (the size of the read-out at that concentration, not a potency): 93.6%
Compound 3: the middle estimate sits 78.6 percentage points below what was measured, outside the stated range (above it).
By their numbers in this assay, from the lowest: compound 2; then compound 1; then compound 3.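

In this assay, trifluoromethyl in place of trifluoromethoxy on this aromatic carbon gives a number 93.6 percentage points higher from compound 2 to compound 3 (beyond the scatter), so the fluorine atoms shared by the two groups do not on their own go with the loss of effect seen for compound 2. Trifluoromethyl in place of methyl gives a number 37.3 percentage points higher from compound 1 to compound 3 (beyond the scatter), which shows that a change at this position can raise the read-out as well as remove it, and that the order among these three groups does not follow the count of heavy atoms alone, since methyl, the smallest, lies in the middle. Nothing among the data shown explains either step.

The compounds shown leave open whether the oxygen link itself goes with the loss of effect, which methoxy, holding the oxygen without fluorine, would address, and whether a chlorine, a nitrile or an amine at this position would follow compound 3 or compound 2. All three numbers come from one concentration on the shared core, so they show only a stronger or weaker effect at that concentration and leave open whether the same order holds at other concentrations or with other substituents elsewhere on the core.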